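This account rests on a few compounds, and the source may have more. Where it says the series, first, only, none or still open, it means among the compounds named here.

Measured in a functional assay on HeLa cells (Homo sapiens) for inhibition, read by sulforhodamine B assay; a lower number here means a stronger inhibitor, a higher number a weaker inhibitor:
- compound 1 `O=C1C(NC2CCCC2)=CC(=O)c2c1nc1n2[C@H]2OC[C@@H](O)[C@H]2OC1`: > 16000 nM (a limit)
- compound 2 `Cc1ccc(NC2=CC(=O)c3c(nc4n3[C@H]3OC[C@@H](O)[C@H]3OC4)C2=O)cc1C`: 4320 nM
- compound 3 `COc1ccc(NC2=CC(=O)c3c(nc4n3[C@H]3OC[C@@H](O)[C@H]3OC4)C2=O)cc1`: > 8000 nM (a limit)

Compound 3 stands only as a limit, > 8000 nM, not as a number. Compound 4 `CCCc1ccc(NC2=CC(=O)c3c(nc4n3[C@H]3OC[C@@H](O)[C@H]3OC4)C2=O)cc1` differs from it by propyl in place of methoxy on an aromatic carbon, with propyl in place of methoxy on an aromatic carbon, para to a large group. For the measured compounds named here, two measured steps bear on this: an at least 1.8-fold higher number from compound 2 to compound 3 (0.26 log units; that floor lies within the scatter), whose floor lies within the scatter, and an at least 3.7-fold lower number from compound 1 to compound 2 (0.56 log units; beyond the scatter), beyond the scatter. Both involve the 3,4-dimethylphenyl of compound 2, which also carries alkyl groups on the phenyl and gives 4320 nM. A modest move to a lower number in this assay is therefore expected, though a further limit remains possible. The expected step is an at least 1.6-fold lower number from compound 3 to compound 4 (0.20 log units; that floor lies within the scatter). For compound 4 the estimated value is 5000 nM, with an expected range of 2000 nM to 12000 nM.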

Compound 4, half-maximal inhibitory concentration: 6030 nM
The estimate for compound 4 lay 1.2-fold (0.08 log units) below the measured number; measured number inside the range.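

In this assay, the 4-propylphenyl of compound 4 gives a number where the 4-methoxyphenyl of compound 3 gives only a limit, and propyl in place of methoxy reads as an at least 1.3-fold lower number from compound 3 to compound 4 (0.12 log units; that floor lies within the scatter). Against the 3,4-dimethylphenyl, the result is a 1.4-fold higher number from compound 2 to compound 4 (0.14 log units; within the scatter), so these two alkyl-bearing phenyl groups cannot be told apart here. Against cyclopentyl, the result is an at least 2.6-fold lower number from compound 1 to compound 4 (0.42 log units; beyond the scatter), so compounds 2 and 4 both improve on cyclopentyl, while compound 3 leaves that comparison unreadable.

On these data alone, the full size of the change from methoxy to propyl stays open, as only its floor can be read. Also open, as far as these compounds go, is how a longer chain, an amine or a carboxylic acid on the aromatic carbon para to a large group would read.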